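The source may report more compounds than this note shows. Statements on the series, on what has been measured and on what is new or still open speak of the compounds shown alone.

Compound 1 `CC1CCN(C2CCN(S(=O)(=O)c3cccc(C(F)(F)F)c3)CC2)CC1` and compound 2 `CC1CCN(C2CCN(S(=O)(=O)c3ccc(Cl)c(C(F)(F)F)c3)CC2)CC1` share one core and differ only at a single aromatic carbon. In a functional assay on DLD-1 cells (Homo sapiens) for antiproliferative activity, read by CellTiter-Glo, with a stated time of 72 h (on this read-out lower numbers stand for stronger inhibition and higher numbers for weaker inhibition), compound 1 gives > 5000 nM, which is a limit of the assay rather than a number. In this assay compound 2 gives 17 nM. The change from compound 1 to compound 2, chloro in place of hydrogen on an aromatic carbon, brings an at least 290-fold lower number from compound 1 to compound 2 (2.46 log units; beyond the scatter); the step can only be given as a bound because of the limit of > 5000 nM in this assay, at which 1 of the 2 values shown sits. Within the data shown here, compound 2 therefore holds the only number measured so far, the other value being a limit.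

Compound 3 `CC1CCN(C2CCN(S(=O)(=O)c3ccc([N+](=O)[O-])c(C(F)(F)F)c3)CC2)CC1` carries nitro in place of chloro on an aromatic carbon. Among the measured compounds shown here, the single measured step concerns a different exchange at the same carbon, so it shows only that this carbon tolerates change poorly in one direction, not how nitro compares with chloro. A moderate weakening is expected, and compound 3 is estimated at 40 nM, with a range from 8 nM to 250 nM. The expected step is a 2.4-fold higher number from compound 2 to compound 3 (0.37 log units; beyond the scatter).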

Compound 3, half-maximal inhibitory concentration: 56 nM
Compound 3: middle estimate off by 1.4-fold (0.15 log units), on the low side; measured number inside the range.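

Nitro in place of chloro brings a 3.3-fold higher number from compound 2 to compound 3 (0.52 log units; beyond the scatter), so chloro is not the only group on this carbon that goes with a low number, although it gives the lower of the two. Measured against hydrogen, nitro brings an at least 89-fold lower number from compound 1 to compound 3 (1.95 log units; beyond the scatter), which means that two different groups on this carbon, para to a large group, now both stand far from the hydrogen compound. That second step can be given only as a bound: the limit of > 5000 nM in this assay, at which 1 of the 3 values shown sits.

What an amine, a methoxy group or a carboxylic acid on this carbon would give remains open, so the compounds shown cannot tell what chloro and nitro have in common that matters here. Going by these compounds, the trifluoromethyl group stays in place in all three compounds, so whether the gain over hydrogen depends on it is also open.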